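Fluoropyridyl replacement on the tetrazole-linked aryl group

This account rests on a few compounds, and the source may have more. Where it says the series, first, only, none or still open, it means among the compounds named here.

For the measured compounds named here, compound 3 `Cc1cc(NC(=O)Cn2nnc(-c3ccc(F)c(F)c3)n2)n(C2CCCCC2)n1` gives 116 nM in an assay on HEK293 cells for activation of Kir3.1/Kir3.2 (Homo sapiens), read by thallium flux (on this read-out lower numbers stand for an effect already at smaller amounts and higher numbers for an effect only at larger amounts of compound), the lowest of the three numbers so far; compound 2 `Cc1cc(NC(=O)Cn2nnc(-c3ccccc3F)n2)n(C2CCCCC2)n1` gives 187 nM and the gap a 1.6-fold lower number from compound 2 to compound 3 (0.21 log units; within the scatter) is within the scatter, so the two are not separated. Compound 1 `Cc1cc(NC(=O)Cn2nnc(-c3ccccn3)n2)n(C2CCCCC2)n1` gives 14600 nM, far from both: a 78-fold lower number from compound 1 to compound 2 (1.89 log units; beyond the scatter) and a 130-fold lower number from compound 1 to compound 3 (2.10 log units; beyond the scatter).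

Compound 4 `Cc1cc(NC(=O)Cn2nnc(-c3ccnc(F)c3)n2)n(C2CCCCC2)n1` is not yet measured. The change is 2-fluoropyridin-4-yl in place of 3,4-difluorophenyl on an aromatic carbon. Going by the values given here, the steps that bear on it are the two from compound 1, where a pyridin-2-yl gave way to a fluorophenyl and the number fell by a large amount in each case; compound 4 moves the other way, from a fluorinated phenyl back to a ring with one nitrogen, although the nitrogen sits in a different ring position and a fluorine remains. A large rise in the number is therefore expected, though perhaps not all the way back to compound 1. For compound 4 in this assay the estimate is 3000 nM, range 500 nM to 20000 nM, an expected step of a 26-fold higher number from compound 3 to compound 4 (1.41 log units; beyond the scatter).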

Compound 4, half-maximal effective concentration: 441 nM
Compound 4: middle estimate off by 6.8-fold (0.83 log units), on the high side; measured number below the stated range.
By their numbers in this assay, from the lowest: compounds 3 and 2 (each within the scatter of the next); then compound 4; then compound 1.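

In this assay, a ring nitrogen in the group on this aromatic carbon does not always bring a large rise: 2-fluoropyridin-4-yl gives only a modest one, with a 3.8-fold higher number from compound 3 to compound 4 (0.58 log units; beyond the scatter) and with a 2.4-fold higher number from compound 2 to compound 4 (0.37 log units; beyond the scatter) as well. Set against pyridin-2-yl, the same group gives a large drop, with a 33-fold lower number from compound 1 to compound 4 (1.52 log units; beyond the scatter), so the six-membered aromatic ring with 1 hetero atom in compound 4 sits close to the fluorophenyl compounds and the one in compound 1 does not. Nothing available here gives a reason for these differences.

Compound 1 and compound 4 differ in both the nitrogen position and the fluorine, and no compound shown separates the two changes. Also open, on these data alone, is how a plain pyridin-4-yl or a 2-aminopyridin-4-yl would read on this aromatic carbon.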